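The compounds below may be only part of what the source reports. "The series", "measured", "known", "first", "only" and "open" are said of these compounds alone.

Working notes on the series, read in a functional assay on NCI-H460 cells (Homo sapiens) for inhibition, read by sulforhodamine B assay, with a stated time of 48 h; on this read-out higher numbers stand for weaker inhibition of growth and lower numbers for stronger inhibition of growth. Compound 1 (`S=C(N/N=C/c1cccs1)Nc1ccc(Cl)cc1`) gives > 100000 nM, which is a limit. Compound 2 (`S=C(N/N=C/c1cccs1)Nc1ccccc1`) gives > 100000 nM, which is also a limit and no number. Compound 3 (`S=C(N/N=C/c1cccs1)Nc1cccc2ccccc12`) gives > 100000 nM, again a limit. Within the data shown here, the whole series so far therefore stands at one mark: the limit of > 100000 nM in this assay, at which 3 of the 3 values shown sit.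

Compound 4 (`Cc1ccc(NC(=S)N/N=C/c2cccs2)cc1`) departs from compound 2 by a single change, (methyl in place of hydrogen on an aromatic carbon), with methyl in place of hydrogen on an aromatic carbon. Among the measured compounds shown here, the one measured step in reach is a step that the two limits leave unreadable from compound 1 to compound 2, so it offers no size to carry over. The expectation rests instead on compound 2 at its limit of > 100000 nM. The expected change is a number no higher from compound 2 to compound 4 (the limit leaves the size open), no larger than the scatter, and a further report of only a limit is the likeliest outcome. For compound 4 the estimated value is 100000 nM, with an expected range from 30000 nM to 200000 nM.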

Compound 4, concentration for 50% growth inhibition: 80600 nM
Estimate against measurement, compound 4: 1.2-fold (0.09 log units) above; low and high end bracket the measured number.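

In this assay, among these compounds, methyl on the aromatic carbon para to a large group gives the first reading that is a number and not a limit, in compound 4. Methyl in place of hydrogen gives an at least 1.2-fold lower number from compound 2 to compound 4 (0.09 log units; that floor lies within the scatter) and methyl in place of chloro gives an at least 1.2-fold lower number from compound 1 to compound 4 (0.09 log units; that floor lies within the scatter) and each step therefore has only a floor, so neither is shown to pass the scatter. The other compounds remain at a single mark: the limit of > 100000 nM in this assay, at which 3 of the 4 values shown sit.

The compounds shown leave open whether an amine, a methoxy group or a longer chain at this same position would give a number clearly apart from that mark. The step between compound 1 and compound 2 cannot be read, since both ends are limits.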